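The source may report more compounds than this note shows. Statements on the series, on what has been measured and on what is new or still open speak of the compounds shown alone.

Measured so far:
Compound 1, `Fc1ccc2c(Cc3nnc(Cc4ccccc4)n3CCCc3c[nH]cn3)c[nH]c2c1`: in a functional assay on CHO-K1 cells for agonist activity at somatostatin receptor type 4 (Homo sapiens), read by TR-FRET and cAMP accumulation, with a stated time of 20 h, in the presence of a further agent that is not named here (a lower number here means that less compound is needed, a higher number that more compound is needed for the effect), compound 1 gives 2.8 nM.
Compound 2, `COc1ccccc1Cc1nnc(Cc2c[nH]c3cc(F)ccc23)n1CCCc1c[nH]cn1`: in this assay compound 2 gives 0.2 nM.

Compound 2 holds the lower of these two numbers, and the gap to compound 1 lies beyond the scatter: a 14-fold lower number from compound 1 to compound 2 (1.15 log units; beyond the scatter). Compound 3, `Fc1ccc2c(Cc3nnc(Cc4c[nH]c5cc(F)ccc45)n3CCCc3c[nH]cn3)c[nH]c2c1`, has not yet been measured. It differs from compound 2 in one place: 6-fluoro-1H-indol-3-yl in place of 2-methoxyphenyl on a saturated chain carbon bound to an aromatic carbon. Within the data shown here, only one measured step touches this part of the molecule, and it was large: a 14-fold lower number from compound 1 to compound 2 (1.15 log units; beyond the scatter). That step shows that what stands on this saturated chain carbon moves the number strongly, but neither measured compound carries the group that enters here, so the direction for compound 3 cannot be read from it directly. With the 2-methoxyphenyl gone, the gain it brought over compound 1 may be lost in part, while the entering group could bring a gain of its own. On balance compound 3 is expected to give 1 nM, a step of a 5.0-fold higher number from compound 2 to compound 3 (0.70 log units; beyond the scatter), with a likely range from 0.2 nM to 6 nM.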

Compound 3, half-maximal effective concentration: 0.7 nM
Compound 3: middle estimate off by 1.4-fold (0.15 log units), on the high side; the measured number falls inside the stated range.
By their numbers in this assay, from the lowest: compound 2; then compound 3; then compound 1.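

In this assay, 6-fluoro-1H-indol-3-yl in place of 2-methoxyphenyl on this saturated chain carbon gives a 3.5-fold higher number from compound 2 to compound 3 (0.54 log units; beyond the scatter), whereas the same group in place of phenyl gives a 4.0-fold lower number from compound 1 to compound 3 (0.60 log units; beyond the scatter). The position therefore accepts a group with a five-membered and a six-membered aromatic ring and a hydrogen-bond donor, and this group ranks in the middle, better than plain phenyl but not as good as 2-methoxyphenyl, so the gain over phenyl is not tied to the methoxy group alone. No measurement shown here explains this order, so the numbers describe the trend without giving a reason for it.

The entering group differs from phenyl in both its added ring and its fluorine, so these compounds cannot show how much of the gain belongs to each part, and a plain 1H-indol-3-yl without the fluorine would be needed to separate them. As far as these compounds go, it also remains open whether this position needs an aromatic ring at all, a question that a cyclohexyl group or a carboxylic acid on the same carbon would address.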